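A Methyl on the Amide Nitrogen: Expected Edema Inhibition

The source may report more compounds than this note shows. Statements on the series, on what has been measured and on what is new or still open speak of the compounds shown alone.

Compound 2 `CN1C/C(=C\c2ccc(-c3cccs3)cc2)C(=O)[C@]2(C1)[C@@H](c1ccc(-c3cccs3)cc1)CN(C)[C@@]21C(=O)Nc2ccccc21` stands highest of the two numbers in a functional assay on the whole organism (strain Wister albino) for inhibition, with Rattus norvegicus as the target, read by paw edema, with stated times of 1 h and 4 h, at a dose of 50 mg/kg by the intraperitoneal route (on this read-out lower numbers stand for less inhibition and higher numbers for more inhibition at the one dose given (going by the name of the read-out)), where compound 2 gives 126%; its nearest neighbour, compound 1 `CN1C/C(=C\c2ccc(Cl)cc2)C(=O)[C@]2(C1)[C@@H](c1ccc(Cl)cc1)CN(C)[C@@]21C(=O)N(C)c2ccccc21`, gives 80.9%, a gap beyond the scatter. Compound 3 `CN1C/C(=C\c2ccc(-c3cccs3)cc2)C(=O)[C@]2(C1)[C@@H](c1ccc(-c3cccs3)cc1)CN(C)[C@@]21C(=O)N(C)c2ccccc21` has not yet been measured; it differs from compound 2 by methyl in place of hydrogen on an amide-type nitrogen in a ring. Going by the values given here, no measured pair shows this change alone, so its size is unknown from the data. The account expects a modest downward step, possibly still within the scatter, a number 21 percentage points lower from compound 2 to compound 3 (beyond the scatter). For compound 3 the estimated value in this assay is 105%, with a range from 70% to 140%.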

Compound 3, a percentage reported as inhibition, in the whole organism at one dose (the size of the read-out at that dose, not a potency): 124%
Compound 3: middle estimate off by 19 percentage points, on the low side; measured number inside the range.
By their numbers in this assay, from the lowest: compound 1; then compounds 3 and 2 (each within the scatter of the next).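

In this assay, going by these compounds alone, methyl in place of hydrogen on the amide-type nitrogen in a ring gives a number 2 percentage points lower from compound 2 to compound 3 (within the scatter), the first reading of this change alone. On this core, then, the amide hydrogen is not required to keep the inhibition at the one dose given, and the added methyl leaves it within the scatter. Nothing measured here gives a reason for this. On these data alone, what an ethyl or a benzyl group on this nitrogen would do remains open. So does whether the same change would matter as little with the chlorine-bearing groups of compound 1.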